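Iodo in place of (trifluoromethyl)carbonyl on the shared core

This account rests on a few compounds, and the source may have more. Where it says the series, first, only, none or still open, it means among the compounds named here.

Three analogues share a core and differ only in the group on the carbonyl carbon. In an assay (Rattus norvegicus) for inhibition of Fatty-acid amide hydrolase 1 (Homo sapiens) (on this read-out higher numbers stand for weaker inhibition and lower numbers for stronger inhibition), compound 1 `CNC(=O)c1cnc(C(=O)CCCCCCc2ccccc2)o1` gives 7 nM. Compound 2 `CC(=O)c1cnc(C(=O)CCCCCCc2ccccc2)o1` gives 2 nM in this assay, and compound 3 `O=C(CCCCCCc1ccccc1)c1ncc(C(=O)C(F)(F)F)o1` gives 4 nM. The steps are small: a 3.5-fold lower number from compound 1 to compound 2 (0.54 log units; beyond the scatter) is the only one beyond the scatter, while a 1.8-fold lower number from compound 1 to compound 3 (0.24 log units; within the scatter) and a 2.0-fold higher number from compound 2 to compound 3 (0.30 log units; within the scatter) stay within it. Compound 3 therefore sits with the second highest of the three numbers, with compound 1 nearest and compound 2 furthest, both within the scatter of it.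

Compound 4 `O=C(CCCCCCc1ccccc1)c1ncc(I)o1` differs from compound 3 by iodo in place of (trifluoromethyl)carbonyl on an aromatic carbon. Among the compounds with values here, no measured step bears on this directly: each step so far exchanges the group on the carbonyl carbon while keeping the carbonyl, whereas here the whole (trifluoromethyl)carbonyl leaves and a single iodine enters. Within the data shown here, the measured steps show only that changes at this position moved this assay by modest amounts. With the carbonyl itself removed, a larger loss is plausible but unsupported by any shown step. For compound 4 the expected value is 20 nM, with a range of 4 nM to 100 nM. The estimated step is accordingly a 5.0-fold higher number from compound 3 to compound 4 (0.70 log units; beyond the scatter), a modest weakening with wide uncertainty.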

Compound 4, inhibition constant: 3 nM
Estimate against measurement, compound 4: 6.7-fold (0.82 log units) above; the whole stated range lies above it.
By their numbers in this assay, from the lowest: compounds 2, 4, 3 and 1 (each within the scatter of the next, the first and the last beyond it).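

Notes on the position on an aromatic carbon next to the ring oxygen: in this assay this position does not depend on keeping a carbonyl in the group it carries. Iodo, one heavy atom with no hydrogen-bond acceptor, cannot be told apart from the groups of compound 3 and compound 2, with a 1.3-fold lower number from compound 3 to compound 4 (0.12 log units; within the scatter) and a 1.5-fold higher number from compound 2 to compound 4 (0.18 log units; within the scatter) both read as within the scatter. Within the data shown here, the only new step beyond the scatter is the modest 2.3-fold lower number from compound 1 to compound 4 (0.37 log units; beyond the scatter) and no account of this tolerance can be given, as nothing measured on these compounds bears on why the exchange of six heavy atoms for one leaves the number in place.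

Still open, going by these compounds, is whether this tolerance belongs to iodo in particular or extends to other groups on this aromatic carbon, such as a hydrogen, a chlorine, a nitrile, an amine or a carboxylic acid, which would show whether anything at this place matters to this read-out. Also open, on these data alone, is whether the same tolerance holds when the chain ending in the phenyl group is shorter or longer, since all the compounds here carry one and the same chain.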